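Halogenated benzyl variation on the dimethoxypyridine sulfonylurea series

A few compounds are considered here, and "the series" means these few. Any claim that something is new, unique, unknown or untested is made for them only; others in the source may bear on it.

Compound 2 `COc1cc(F)c(CN2C(=O)N(c3cnc(OC)c(OC)c3)S(=O)(=O)c3ccccc32)c(F)c1` holds the lowest number of the three measured in an assay on isolated protein for displacement of a labelled ligand from Orexin/Hypocretin receptor type 1 (Homo sapiens), with a stated time of 90 min (on this read-out lower numbers stand for stronger inhibition and higher numbers for weaker inhibition), at 2.51 nM. Compound 1 `COc1ccc(N2C(=O)N(Cc3c(F)cc(F)cc3F)c3ccccc3S2(=O)=O)cc1OC` gives 50.1 nM and compound 3 `COc1ccc(N2C(=O)N(Cc3ccccc3)c3ccccc3S2(=O)=O)cc1OC` gives 2000 nM. Among the measured compounds shown here, the one step measured at the same place, a 40-fold higher number from compound 1 to compound 3 (1.60 log units; beyond the scatter), shows that stripping the halogens from the benzyl ring costs a great deal. Compound 4 `COc1cc(N2C(=O)N(Cc3c(F)cc(F)cc3Cl)c3ccccc3S2(=O)=O)cnc1OC` carries the change (2-chloro-4,6-difluorophenyl in place of 2,6-difluoro-4-methoxyphenyl on a saturated chain carbon bound to an amide-type nitrogen in a ring); unlike that step, it keeps a fully halogenated ring, exchanging one fluorine for chlorine and losing the methoxy. Compound 2 and compound 1 differ at both the core and this ring, so the methoxy's own weight is not resolved. The expectation is a small step, a 1.6-fold higher number from compound 2 to compound 4 (0.20 log units; within the scatter), within or near the scatter. Compound 4 is therefore estimated at 4 nM, with a range of 1.3 nM to 12 nM.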

Compound 4, inhibition constant: 39.8 nM
Estimate against measurement, compound 4: 10-fold (1.00 log units) below; measured number outside the range, above it.
By their numbers in this assay, from the lowest: compound 2; then compounds 4 and 1 (each within the scatter of the next); then compound 3.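

In this assay, 2-chloro-4,6-difluorophenyl in place of 2,6-difluoro-4-methoxyphenyl gives a 16-fold higher number from compound 2 to compound 4 (1.20 log units; beyond the scatter) on the shared core. The earlier step showed a large change when the halogens were removed, whereas this one shows that this position also responds strongly when both rings carry two fluorines. No supporting data explain the size of this step.

Methoxy leaves and chlorine enters in the same step, so their separate contributions remain unresolved. As far as these compounds go, how an amine or a longer alkoxy chain on this ring would read also stays open.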